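Swapping cyclopentyl for hexyl on a very weak binder

The compounds below may be only part of what the source reports. "The series", "measured", "known", "first", "only" and "open" are said of these compounds alone.

Compound 1 `CCCCCCNc1nc(-c2ccccc2)nc2c1nnn2Cc1ccccc1` and compound 2 `Clc1ccccc1Cn1nnc2c(NC3CCCC3)nc(-c3ccccc3)nc21` were both tested in an assay on isolated protein for binding affinity to adenosine receptor A1 (Bos taurus); on this read-out higher numbers stand for weaker inhibition and lower numbers for stronger inhibition. Compound 1 gives 13200000 nM and compound 2 gives 9000000 nM, so compound 2 stands within the usual scatter of compound 1 and neither stands apart. Compound 3 `CCCCCCNc1nc(-c2ccccc2)nc2c1nnn2Cc1ccccc1Cl` differs from compound 2 by hexyl in place of cyclopentyl on a nitrogen on an aromatic ring. Within the data shown here, no measured pair shows this change alone, so the expected step from compound 2 to compound 3 in this assay is none beyond the scatter, a 1.3-fold higher number from compound 2 to compound 3 (0.12 log units; within the scatter). Compound 3 is therefore estimated at 12000000 nM, with a range from 4000000 nM to 36000000 nM.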

Compound 3, inhibition constant: 31000000 nM
For compound 3 the middle estimate is 2.6-fold (0.41 log units) below the measured one; low and high end bracket the measured number.
By their numbers in this assay, from the lowest: compounds 2 and 1 (each within the scatter of the next); then compound 3.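

Hexyl in place of cyclopentyl on the nitrogen gives a 3.4-fold higher number from compound 2 to compound 3 (0.54 log units; beyond the scatter), so this position responds to the change, and the open chain goes with weaker inhibition. Chloro in place of hydrogen on an aromatic carbon, with hexyl kept on the nitrogen, also weakens inhibition, giving a 2.3-fold higher number from compound 1 to compound 3 (0.37 log units; beyond the scatter). Nothing measured here explains either modest step.

On these data alone, it remains open whether a butyl chain or a cyclohexyl ring on that nitrogen would follow the same trend. As far as these compounds go, whether chloro has the same effect with cyclopentyl on the nitrogen also remains unknown.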